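The source may hold more compounds than are shown below. What is called first, only, known or untested is meant among the compounds shown, and "the series" means these compounds.

Of the compounds shown here, three sharing one core have been measured in a functional assay on cells for agonist activity at Glucose-dependent insulinotropic receptor (Homo sapiens), read by HTRF and cAMP accumulation, with a stated time of 30 min; a higher number here means that more compound is needed for the effect, a lower number that less compound is needed. Compound 1 `CC(C)(C)OC(=O)N1CCC2(CC1)CC(CCCOc1ccc(S(C)(=O)=O)cc1)C2` gives 14 nM. Compound 2 `CC(C)OC(=O)N1CCC2(CC1)CC(CCCOc1ccc(S(C)(=O)=O)cc1)C2` gives 78 nM, and compound 3 `CCc1cnc(N2CCC3(CC2)CC(CCCOc2ccc(S(C)(=O)=O)cc2)C3)nc1` gives 31 nM. Among these three numbers compound 3 stands second highest. The step of a 5.6-fold higher number from compound 1 to compound 2 (0.75 log units; beyond the scatter) is the largest, while a 2.2-fold higher number from compound 1 to compound 3 (0.35 log units; beyond the scatter) and a 2.5-fold lower number from compound 2 to compound 3 (0.40 log units; beyond the scatter) are smaller, so the group on the ring nitrogen clearly matters.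

Compound 4 `Cc1ccc(N2CCC3(CC2)CC(CCCOc2ccc(S(C)(=O)=O)cc2)C3)nc1` differs from compound 3 in that (5-methylpyridin-2-yl in place of 5-ethylpyrimidin-2-yl on an amine nitrogen in a ring). Going by the values given here, no measured step exchanges one aromatic ring for another on this nitrogen; the steps 1 to 3 and 2 to 3 only show that replacing a carbamate by the aromatic ring shifts the number modestly in either direction. The new change is therefore expected to give at most a modest step, with no firm direction, and most likely one that stays near compound 3. For compound 4 the estimate is 35 nM, with a range from 12 nM to 100 nM, corresponding to an expected step of a 1.1-fold higher number from compound 3 to compound 4 (0.05 log units; within the scatter).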

Compound 4, half-maximal effective concentration: 348 nM
Compound 4: the middle estimate sits 9.9-fold (1.00 log units) below what was measured; the measured number lies above the stated range.
By their numbers in this assay, from the lowest: compound 1; then compound 3; then compound 2; then compound 4.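

In this assay the group on the amine nitrogen in a ring proves sensitive even when one aromatic ring replaces another, with an 11-fold higher number from compound 3 to compound 4 (1.05 log units; beyond the scatter) as a large step that exceeds every step among the first three compounds. The 5-methylpyridin-2-yl group also falls behind both carbamates, as shown by a 4.5-fold higher number from compound 2 to compound 4 (0.65 log units; beyond the scatter) and by a 25-fold higher number from compound 1 to compound 4 (1.40 log units; beyond the scatter), so an aromatic ring on this nitrogen does not by itself keep the number low. Nothing measured here gives a reason for these steps.

The change swaps two things at once, a ring with 2 hetero atoms for one with 1 and ethyl for methyl, and the compounds shown cannot separate the two. A 5-methylpyrimidin-2-yl or a 5-ethylpyridin-2-yl group on this nitrogen would tell them apart.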